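A few compounds are considered here, and "the series" means these few. Any claim that something is new, unique, unknown or untested is made for them only; others in the source may bear on it.

Measured so far:
compound 1 `CNc1ncc2c(-c3ccc(N4CCNCC4)nc3)nn(Cc3cn(Cc4ccccc4)nn3)c2n1` — > 10000 nM
compound 2 `CCN1CCN(c2ccc(-c3nn(Cc4cn(Cc5ccccc5)nn4)c4nc(NC)ncc34)cn2)CC1` — 1900 nM

In an assay for inhibition of tyrosine-protein kinase receptor TYRO3 (Homo sapiens), read by 33P incorporation, in the presence of a further agent that is not named here (a lower number here means a stronger inhibitor, a higher number a weaker inhibitor), compound 1 reaches only a limit, > 10000 nM. Within the data shown here, compound 2 gives the only number in this assay, 1900 nM. The other value shown, that of compound 1, is a limit. Among the measured compounds shown here, the single measured step, an at least 5.2-fold lower number from compound 1 to compound 2 (0.72 log units; beyond the scatter), rests on that limit (the limit of > 10000 nM in this assay, at which 1 of the 2 values shown sits).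

Compound 3 `CNc1ncc2c(-c3ccc(N4CCN(C(=O)C(C)(C)C)CC4)nc3)nn(Cc3cn(Cc4ccccc4)nn3)c2n1` carries (tert-butyl)carbonyl in place of ethyl on an amine nitrogen in a ring. For the measured compounds named here, no measured step covers this replacement; the step from hydrogen to ethyl concerns a different group on the same ring nitrogen and gives only a weak guide. Compound 3 is therefore estimated near 3000 nM, within 800 nM to 15000 nM. The expected step reads a 1.6-fold higher number from compound 2 to compound 3 (0.20 log units; within the scatter), within scatter or modestly weaker.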

Compound 3, half-maximal inhibitory concentration: > 10000 nM
Compound 3 was reported as a limit; the forecaster's own chance of this, stated with the estimate: 25%; middle value at least 3.3-fold (0.52 log units) away from the limit.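

In this assay, replacing 4-ethylpiperazin-1-yl with 4-((tert-butyl)carbonyl)piperazin-1-yl gives an at least 5.2-fold higher number from compound 2 to compound 3 (0.72 log units; beyond the scatter), a step resting on the limit of compound 3. Substitution on this ring nitrogen therefore does not lower the number in every case: ethyl does, while (tert-butyl)carbonyl does not keep that gain. The step between compound 1 and compound 3 cannot be read, as both ends are limits: the limit of > 10000 nM in this assay, at which 2 of the 3 values shown sit.

As far as these compounds go, it remains open whether the carbonyl or the tert-butyl part drives the change. Also open, from the compounds shown here alone, is how a propyl chain or a simple acetyl on this nitrogen would compare with ethyl.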